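The source may report more compounds than this note shows. Statements on the series, on what has been measured and on what is new or still open speak of the compounds shown alone.

Working notes on the series.

Three analogues of the shared core have been measured in a functional assay on IGROV-1 cells (Homo sapiens) for inhibition, read by sulforhodamine B assay, with a stated time of 48 h; on this read-out higher numbers stand for weaker inhibition of growth and lower numbers for stronger inhibition of growth. Compound 1 `Nc1cc(N)c2nc(-c3ccccc3)c(Oc3ccc(Cl)c(Cl)c3)nc2c1` gives 11500 nM in this assay, which is the highest of the three numbers recorded. Compound 2 `Nc1cc(N)c2nc(-c3ccccc3)c(NCc3ccc(Cl)c(Cl)c3)nc2c1` gives 1950 nM in this assay, the lowest of the three; compound 3 `CCOC(=O)[C@H](CCC(=O)O)NC(=O)c1ccc(Sc2nc3cc(N)cc(N)c3nc2-c2ccccc2)cc1` gives 4790 nM in this assay. Both of these gaps from compound 1 lie beyond the scatter, so on the numbers shown compound 1 is the weakest inhibitor of growth of the three.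

The step under consideration goes from compound 1 to compound 4 `Nc1cc(N)c2nc(-c3ccccc3)c(Oc3ccc(F)cc3)nc2c1`. The change is 4-fluorophenyl in place of 3,4-dichlorophenyl on an oxygen on an aromatic ring. Among the compounds with values here, no pair among the measured compounds shares this change, so there is no direct reference for its size. Given that, the step from compound 1 to compound 4 is expected to be small, within or close to the scatter, and if anything toward a somewhat higher number, a 1.3-fold higher number from compound 1 to compound 4 (0.12 log units; within the scatter). Compound 4 is therefore expected to give about 15000 nM in this assay, with a plausible range from 5000 nM to 45000 nM, and the measured value will show whether compound 4 stays near compound 1 or moves toward compound 3 and compound 2.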

Compound 4, concentration for 50% growth inhibition: 28200 nM
Estimate against measurement, compound 4: 1.9-fold (0.27 log units) below, within the range that was stated.
By their numbers in this assay, from the lowest: compound 2; then compound 3; then compound 1; then compound 4.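

In this assay, within the data shown here, 4-fluorophenyl in place of 3,4-dichlorophenyl on an oxygen on an aromatic ring gives a 2.5-fold higher number from compound 1 to compound 4 (0.39 log units; beyond the scatter), and this is the first step that can be read for a single change, as no earlier pair differs in one place only. It shows that the number responds to the group carried on this oxygen, with the core and the oxygen held fixed and the 3,4-dichlorophenyl the better of the two groups compared here. Nothing measured here speaks to the origin of this step.

The step removes both chlorines and brings in a fluorine at once, so the compounds shown do not separate these changes; an unsubstituted phenyl or a phenyl carrying a single chlorine on this oxygen would begin to do so. Also open, as far as these compounds go, is whether the same exchange of groups would give a step of similar size with an amine in place of the oxygen, or whether a carboxylic acid on the ring would move the number in either direction.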